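This account rests on a few compounds, and the source may have more. Where it says the series, first, only, none or still open, it means among the compounds named here.

Measured so far in a functional assay on SK-OV-3 cells (Homo sapiens) for inhibition, read by CCK-8 assay, with a stated time of 70 h; a lower number here means a stronger inhibitor, a higher number a weaker inhibitor
- compound 1 `Clc1ccc(COc2ccc(OCCOCCNC3CCCCC3)cc2)cc1` gives 2650 nM
- compound 2 `c1ccc(COc2ccc(OCCOCCNc3ccncc3)cc2)cc1` gives 20600 nM
- compound 3 `COc1cc(OCCOCCNC2CCCC2)ccc1OCc1ccccc1` gives 44600 nM

Compound 2 stands second highest of these three numbers. Its value lies below that of compound 3 and above that of compound 1, and both gaps are beyond the scatter.

The next compound is compound 4 `c1ccc(COc2ccc(OCCOCCNC3CCC3)cc2)cc1`, which carries cyclobutyl in place of pyridin-4-yl on an amine nitrogen. For the measured compounds named here, no two measured compounds differ in one place only, so the size of this step cannot be read directly from the series. Compound 1 (2650 nM) and compound 3 (44600 nM) also have a non-aromatic ring of carbon only on that nitrogen. They fall on either side of compound 2 (20600 nM), and both also differ from it elsewhere on the shared core, so they give only weak guidance on direction.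

In this assay a small move toward a lower number is therefore expected, one that stays within the scatter. The estimated step is a 1.5-fold lower number from compound 2 to compound 4 (0.17 log units; within the scatter) and remains uncertain in direction. For compound 4 the expected value is 14000 nM, with an estimated range of 4500 nM to 40000 nM for this measurement.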

Compound 4, half-maximal inhibitory concentration: 25000 nM
Compound 4: middle estimate off by 1.8-fold (0.25 log units), on the low side, and the stated range covers the measured number.
By their numbers in this assay, from the lowest: compound 1; then compounds 2, 4 and 3 (each within the scatter of the next, the first and the last beyond it).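

In this assay, the series now has its first step that can be read in one place: a 1.2-fold higher number from compound 2 to compound 4 (0.08 log units; within the scatter). On an amine nitrogen whose other neighbour is a saturated chain carbon, cyclobutyl in place of pyridin-4-yl therefore leaves the number within the scatter, so compound 2 and compound 4 are not told apart by this read-out. The exchange removes a six-membered aromatic ring with 1 hetero atom and its hydrogen-bond acceptor, and brings in a smaller four-membered non-aromatic ring of carbon only, yet this single pair shows no measurable change at this position on the shared core.

Steps involving compound 1 and compound 3 cannot be read, as both also differ from compound 2 and compound 4 elsewhere on the core, so the effect of their larger non-aromatic rings on this nitrogen stays open. Also open, as far as these compounds go, is whether this flat result extends to other groups at the same position, such as a phenyl, a morpholine or a longer chain bearing a carboxylic acid.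

No measured property is available that bears on this step.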